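Thioether link in place of ether link

A few compounds are considered here, and "the series" means these few. Any claim that something is new, unique, unknown or untested is made for them only; others in the source may bear on it.

Within the data shown here, compound 3 `CC(Oc1cccc(Cl)c1)c1nc(N)nc(N2CCN(C)CC2)n1` gives 118 nM in an assay on HEK293 cells for displacement of a labelled ligand from 5-hydroxytryptamine receptor 6 (Homo sapiens), read by radioligand binding, with a stated time of 1 h (on this read-out higher numbers stand for weaker inhibition and lower numbers for stronger inhibition), the second highest of the three numbers so far; compound 1 `CN1CCN(c2nc(N)nc(COc3cccc(Cl)c3)n2)CC1` at 148 nM and compound 2 `Cc1ccccc1OCc1nc(N)nc(N2CCN(C)CC2)n1` at 87 nM both sit within the scatter of it. Compound 4 `CC(Sc1ccccc1Cl)c1nc(N)nc(N2CCN(C)CC2)n1` differs from compound 3 by (2-chlorophenyl)sulfanyl in place of 3-chlorophenoxy on a saturated chain carbon bound to an aromatic carbon and a saturated chain carbon. Among the measured compounds shown here, no measured step touches the oxygen link itself; the nearest comparisons are a 1.7-fold lower number from compound 1 to compound 2 (0.23 log units; within the scatter), which exchanges the ring on that oxygen, and a 1.3-fold lower number from compound 1 to compound 3 (0.10 log units; within the scatter), which adds a methyl at the linking carbon. Both fall within the scatter, so compound 4 is expected to show no step beyond the scatter, a 1.0-fold higher number from compound 3 to compound 4 (0.01 log units; within the scatter). Compound 4 is therefore estimated at 120 nM, with a range of 45 nM to 320 nM.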

Compound 4, inhibition constant: 19 nM
For compound 4 the middle estimate is 6.3-fold (0.80 log units) above the measured one, and the stated range ends above it.
By their numbers in this assay, from the lowest: compound 4; then compounds 2, 3 and 1 (each within the scatter of the next).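

(2-chlorophenyl)sulfanyl in place of 3-chlorophenoxy gives, in this assay, a 6.2-fold lower number from compound 3 to compound 4 (0.79 log units; beyond the scatter), the first step beyond the scatter in this series; the earlier exchange of the ring on the oxygen and the added methyl both stayed within it. This single exchange alters two things at once, sulfur replacing the oxygen link and the chlorine changing its place on the ring, so the step cannot be assigned to either. Nothing available bears on the cause of this step.

Which of the two alterations carries the step remains open; 2-chlorophenoxy or (3-chlorophenyl)sulfanyl at this place would separate them. Also open, going by these compounds, is whether the step persists with hydrogen in place of the methyl on the linking carbon.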